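This account rests on a few compounds, and the source may have more. Where it says the series, first, only, none or still open, it means among the compounds named here.

Notes on the series. Compound 1 `O=c1[nH]cc(S(=O)(=O)Nc2ccccc2-c2cn(-c3cccc(Cl)c3)nn2)c(=O)[nH]1`, compound 2 `O=c1[nH]cc(S(=O)(=O)Nc2cccc(-c3cn(-c4cccc(F)c4)nn3)c2)c(=O)[nH]1`, compound 3 `Cc1ccccc1-n1cc(-c2ccc(NS(=O)(=O)c3c[nH]c(=O)[nH]c3=O)cc2)nn1` and compound 4 `O=c1[nH]cc(S(=O)(=O)Nc2ccc(-c3cn(-c4ccccc4Cl)nn3)cc2)c(=O)[nH]1` share one core and differ in the aryl group on it. In an ADME assay on L02 cells (Homo sapiens) for cytotoxicity, read by MTT assay, with a stated time of 24 h (on this read-out lower numbers stand for higher toxicity in this test and higher numbers for lower toxicity in this test), compound 1 gives only a limit of the assay, > 100000 nM. In this assay compound 2 gives "not toxic" (no number reported). In this assay compound 3 gives "not toxic" (no number reported), so no single number places compound 3. Of the other two entries, that of compound 2 has no number, and that of compound 1 sits at a limit of the assay, as in the limit of > 100000 nM in this assay, at which 1 of the 3 values shown sits. Compound 4 differs from compound 3 by chloro in place of methyl on an aromatic carbon. Going by the values given here, no measured step is available; no shift beyond the scatter is expected for compound 4. For compound 4 in this assay the estimate is 100000 nM, expected between 50000 nM and 200000 nM.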

Compound 4, half-maximal cytotoxic concentration: 19300 nM
Beside the measured number, compound 4's estimate is 5.2-fold (0.71 log units) above it, and the stated range ends above it.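

Going by these compounds alone, compound 3 has no number in this assay, so no step to compound 4 can be read. The compounds shown leave open whether 2-methylphenyl and 2-chlorophenyl differ on this read-out, and where compound 1 stands, its entry being a limit: the limit of > 100000 nM in this assay, at which 1 of the 4 values shown sits.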